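Phenyl group variation on the ring amine nitrogen

This account rests on a few compounds, and the source may have more. Where it says the series, first, only, none or still open, it means among the compounds named here.

Measured so far:
compound 1 `Nc1scc(CN2CCN(c3cc(Cl)cc(Cl)c3)CC2)c1C(=O)c1ccc(Cl)cc1`: 1%
compound 2 `Nc1scc(CN2CCN(c3ccc(F)cc3Cl)CC2)c1C(=O)c1ccc(Cl)cc1`: 0%
compound 3 `Nc1scc(CN2CCN(c3cccc(C(F)(F)F)c3)CC2)c1C(=O)c1ccc(Cl)cc1`: 0%

In an assay on CHO cells for displacement of a labelled ligand from adenosine receptor A1 (Homo sapiens), read by scintillation counting, with a stated time of 120 min, tested at 10 uM (a higher number here means more inhibition at the concentration tested (going by the name of the read-out), a lower number less inhibition), compound 2 gives 0% and stands level with compound 3 at the digits printed, the two together the lowest of the three numbers; the step of a number 1 percentage points lower from compound 1 to compound 2 (within the scatter) and the step of no change at the digits printed from compound 2 to compound 3 (within the scatter) are both within the scatter.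

Compound 4 `Nc1scc(CN2CCN(c3cccc(F)c3)CC2)c1C(=O)c1ccc(Cl)cc1` differs from compound 2 only at the ring amine nitrogen: 3-fluorophenyl in place of 2-chloro-4-fluorophenyl on an amine nitrogen in a ring.

Among the compounds with values here, three steps bear on this change, all of them exchanges of one phenyl group for another at the same nitrogen: a number 1 percentage points lower from compound 1 to compound 2 (within the scatter), a number 1 percentage points lower from compound 1 to compound 3 (within the scatter) and no change at the digits printed from compound 2 to compound 3 (within the scatter), none beyond the scatter. A fourth such exchange is therefore expected to give no step beyond the scatter, a number 1 percentage points higher from compound 2 to compound 4 (within the scatter). For compound 4 in this assay the estimate is 1%, with a range from -6% to 8%.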

Compound 4, a percentage reported as inhibition, at one concentration (the size of the read-out at that concentration, not a potency): 1%
Estimate against measurement, compound 4: no gap at the digits printed; low and high end bracket the measured number.
By their numbers in this assay, from the lowest: compounds 2, 3, 1 and 4 (each within the scatter of the next).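

Fluoro in place of trifluoromethyl on an aromatic carbon extends the set to a direct exchange of the group on the phenyl ring, and it gives a number 1 percentage points higher from compound 3 to compound 4 (within the scatter) in this assay. The smaller 3-fluorophenyl, with 7 heavy atoms, also gives a number 1 percentage points higher from compound 2 to compound 4 (within the scatter) and no change at the digits printed from compound 1 to compound 4 (within the scatter), so fluoro and chloro patterns on this phenyl group remain indistinguishable here. No measurement on record explains this flat result.

Open, on these data alone, is whether an unsubstituted phenyl, a pyridine or a phenyl bearing a carboxylic acid or an amine on this nitrogen would give a readable number. Open too, as far as these compounds go, is whether any group at this position matters on the shared core.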